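Bromo in place of ethylsulfanyl: lipophilicity notes

The source may hold more compounds than are shown below. What is called first, only, known or untested is meant among the compounds shown, and "the series" means these compounds.

Compound 1 `CCSc1ccccc1C1=NC(c2ccccc2)CO1`: 4.04
Compound 2 `FC(F)(F)c1ccccc1-c1ncco1`: 2.15

In a physicochemical assay for lipophilicity (a higher number here means a more lipophilic compound, a lower number a more polar compound), compound 1 stands highest of the two measured compounds, and compound 2 lies lower, beyond the scatter. Compound 3 `Brc1ccccc1C1=NC(c2ccccc2)CO1` is the next to be read. The change bromo in place of ethylsulfanyl on an aromatic carbon puts bromo in place of ethylsulfanyl on an aromatic carbon. Within the data shown here, no measured pair shows a step of this kind, so the expectation rests on the structural change alone. The estimated step of a number 0.24 log units lower from compound 1 to compound 3 (within the scatter) is small and downward, possibly not beyond the scatter. Compound 3 is expected at 3.8 with 3.3 to 4.2 as its expected range.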

Compound 3, partition coefficient: 3.69
Beside the measured number, compound 3's estimate is 0.11 log units above it, and the stated range covers the measured number.
By their numbers in this assay, from the lowest: compound 2; then compound 3; then compound 1.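

In this assay, among these compounds, bromo in place of ethylsulfanyl on an aromatic carbon ortho to a large group gives a number 0.35 log units lower from compound 1 to compound 3 (beyond the scatter) as the first step that changes one place only. The step is modest, yet it shows that this position can register a change beyond the scatter with the rest of the core of compound 1 held constant. Compound 2 differs in more than one place and gives no reading of this change.

Going by these compounds, how an amine, a carboxylic acid or a longer chain at this aromatic carbon would compare remains open. No measurement at hand bears on the cause of this step.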